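Changing the Amide Aryl Group of Compound 3

The compounds below may be only part of what the source reports. "The series", "measured", "known", "first", "only" and "open" are said of these compounds alone.

Compound 3 `Cn1cnc(S(=O)(=O)N2C[C@@H]3[C@H](C2)[C@@]3(CNC(=O)c2cc(Cl)cc(Cl)c2)CC2CC2)c1` gives 100 nM in an assay on isolated protein for inhibition of sodium- and chloride-dependent glycine transporter 1 (Homo sapiens) (a lower number here means a stronger inhibitor, a higher number a weaker inhibitor), the lowest of the two numbers shown. Its nearest neighbour, compound 1 `CC(C)S(=O)(=O)N1C[C@@H]2[C@H](C1)[C@@]2(CNC(=O)c1ccc(Cl)cc1Cl)CC1CC1`, gives 3400 nM. Compound 2 `O=C(NC[C@]1(CC2CC2)[C@@H]2CN(S(=O)(=O)c3ccccc3F)C[C@@H]21)c1ccc(Cl)cc1Cl` reaches only a limit, > 10000 nM. Going by the values given here, the single measured step, an at least 2.9-fold higher number from compound 1 to compound 2 (0.46 log units; beyond the scatter), concerns the sulfonyl substituent and so does not bear on the change at hand, (2-chlorophenyl in place of 3,5-dichlorophenyl on a carbonyl carbon), which gives compound 4 `Cn1cnc(S(=O)(=O)N2C[C@@H]3[C@H](C2)[C@@]3(CNC(=O)c2ccccc2Cl)CC2CC2)c1`. Compounds 1 and 3 differ in two places at once, so their two values cannot be read as one step. Among the compounds with values here, no measured step touches the amide aryl group, and the expectation is correspondingly uncertain. The change is expected to raise the number, a step of a 6.0-fold higher number from compound 3 to compound 4 (0.78 log units; beyond the scatter). Compound 4 is estimated at 600 nM, with a range from 120 nM to 4000 nM.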

Compound 4, half-maximal inhibitory concentration: 19 nM
Beside the measured number, compound 4's estimate is 32-fold (1.50 log units) above it, outside the stated range (below it).
By their numbers in this assay, from the lowest: compound 4; then compound 3; then compound 1. At a limit, above all of these: compound 2.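

In this assay, going by these compounds alone, the change to 2-chlorophenyl gives a 5.3-fold lower number from compound 3 to compound 4 (0.72 log units; beyond the scatter) and so shows that the amide aryl group alone can move the number, which no earlier step could show. The 3,5-dichlorophenyl group is therefore not required for this level of inhibition, since the group with one chlorine fewer gives the lower number with the rest of the molecule unchanged. Nothing shown here gives a cause for this step.

As far as these compounds go, it stays open whether the remaining chlorine contributes at all, and how unsubstituted phenyl, 2-methoxyphenyl or a pyridine ring would compare on this carbonyl carbon. From the compounds shown here alone, whether 2-chlorophenyl has the same effect with an isopropyl group on the sulfonyl sulfur also stays open.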